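The compounds below may be only part of what the source reports. "The series", "measured", "known", "first", "only" and "open" are said of these compounds alone.

Compound 2 `Cc1ccc2[nH]c(C(=O)N[C@H]3CCN(S(=O)(=O)N4CCCCC4)C[C@@H]3C(=O)NCCN(C)C)cc2c1` stands highest of the two numbers in hand: in an ADME assay on cells (Hepatocyte, Rattus norvegicus) for metabolic stability (a higher number here means faster removal of the compound, a lower number slower removal), compound 2 gives 25 uL/min, whereas compound 1 `Cc1ccc2[nH]c(C(=O)N[C@H]3CCN(S(=O)(=O)c4cccnc4)C[C@@H]3C(=O)NCCN(C)C)cc2c1` gives 5 uL/min. Among the compounds with values here, the single measured step, a 5.0-fold higher number from compound 1 to compound 2 (0.70 log units; beyond the scatter), swaps the group on the sulfonyl sulfur. Compound 3 `Cc1ccc2[nH]c(C(=O)N[C@H]3CCN(S(=O)(=O)N4CCOCC4)C[C@@H]3C(=O)NCCN(C)C)cc2c1` differs from compound 2 by morpholin-4-yl in place of piperidin-1-yl on a sulfonyl sulfur. Within the data shown here, no measured step involves morpholin-4-yl, so that step only sets the scale of what a change at this position can do. For compound 3 a modest step down, or none beyond the scatter, is expected: a 2.1-fold lower number from compound 2 to compound 3 (0.32 log units; beyond the scatter). Compound 3 is estimated at 12 uL/min, within 5 uL/min to 30 uL/min.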

Compound 3, intrinsic clearance in a liver preparation (reported as CLH), per the amount of preparation that the assay uses: 6 uL/min
Compound 3: the middle estimate sits 2.0-fold (0.30 log units) above what was measured, within the range that was stated.
By their numbers in this assay, from the lowest: compounds 1 and 3 (each within the scatter of the next); then compound 2.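

In this assay, a single change within the six-membered non-aromatic ring on the sulfonyl sulfur, morpholin-4-yl for piperidin-1-yl, gives a 4.2-fold lower number from compound 2 to compound 3 (0.62 log units; beyond the scatter). A non-aromatic ring at this position therefore does not by itself set the higher number, since morpholin-4-yl in place of pyridin-3-yl gives a 1.2-fold higher number from compound 1 to compound 3 (0.08 log units; within the scatter). Nothing available explains either step.

Open, going by these compounds, is where a piperazin-1-yl ring or an open-chain dimethylamino group on the sulfonyl sulfur would fall. Also open, on these data alone, is whether the step from piperidin-1-yl to morpholin-4-yl holds with another group on the indole-free end of the series.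

Correction to the last sentence: it is open whether this step holds when the shared core carries a different amide chain.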